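Four Related Compounds at the Cytotoxicity Limit

This account rests on a few compounds, and the source may have more. Where it says the series, first, only, none or still open, it means among the compounds named here.

Compound 1 `CCOC(=O)c1c(-c2cccc(-c3ccccc3)c2)[nH]c2cc(OC)ccc2c1=O` was examined in an ADME assay on BJ cells (Homo sapiens) for cytotoxicity, read by luminescence, with a stated time of 72 h; on this read-out lower numbers stand for an effect already at smaller amounts and higher numbers for an effect only at larger amounts of compound. In this assay compound 1 gives > 21500 nM, which is a limit of the assay and not a number. Compound 2 `CCOC(=O)c1c(-c2cccc(OC)c2)[nH]c2cc(OC)ccc2c1=O` differs from it by methoxy in place of phenyl on an aromatic carbon. In this assay compound 2 gives > 21500 nM, again a limit. The step that the two limits leave unreadable from compound 1 to compound 2 therefore has no readable size. Compound 3 `CCOC(=O)c1c(-c2cccc(-c3ccccc3)c2)[nH]c2cc(Cl)c(Cl)cc2c1=O` carries a different core; the difference between the two cores is not broken down here. In this assay compound 3 gives > 21500 nM, once more a limit. Compound 4 `CCOC(=O)c1c(-c2cccc(OC)c2)[nH]c2cc(Cl)c(Cl)cc2c1=O` has not yet been measured; it differs from compound 3 by methoxy in place of phenyl on an aromatic carbon, the same change, in the same place, as from compound 1 to compound 2. Among the compounds with values here, what is known rests on (the limit of > 21500 nM in this assay, at which 3 of the 3 values shown sit), which offers no step of measurable size. Compound 4 is expected to give about 35000 nM in this assay, between 15000 nM and 120000 nM, and most probably to be reported only as a limit. The expected step that the limit leaves unreadable from compound 3 to compound 4 is accordingly estimated to be small.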

Compound 4, half-maximal effective concentration: > 21500 nM
Compound 4 was reported as a limit; the forecaster's own chance of this, stated with the estimate: 85%; the middle value does not contradict the limit.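

Within the data shown here, compound 3 and compound 4 both stand at a limit in this assay, so no step of readable size can be drawn between them. The compounds shown leave open at what concentration each would show an effect, and whether methoxy in place of phenyl changes that effect at all, as the record so far stands: the limit of > 21500 nM in this assay, at which 4 of the 4 values shown sit.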